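The source may report more compounds than this note shows. Statements on the series, on what has been measured and on what is new or still open speak of the compounds shown alone.

In a functional assay on MIA PaCa-2 cells (Homo sapiens) for inhibition, read by MTT assay, with a stated time of 7 days (on this read-out lower numbers stand for stronger inhibition and higher numbers for weaker inhibition), compound 1 `CCOC(=O)C1CCN(S(=O)(=O)c2ccc(S(=O)(=O)N(CC)CC)cc2)CC1` gives 27200 nM and compound 3 `CCN(CC)S(=O)(=O)c1ccc(S(=O)(=O)N2CCC[C@@H](C(=O)N3CC4(CN(C(=O)OC(C)(C)C)C4)C3)C2)cc1` gives 400 nM while compound 2 `CC(C)c1noc(N2CCN(C(=O)[C@@H]3CCCN(S(=O)(=O)c4ccc(S(=O)(=O)C5CCC5)cc4)C3)CC2)n1` gives 70 nM as the lowest number of the three. Compound 2 is therefore the most potent of them, and its gaps to both others lie beyond the usual scatter. Compound 4 `CCN(CC)S(=O)(=O)c1ccc(S(=O)(=O)N2CCC[C@@H](C(=O)N3CCN(c4nc(C(C)C)no4)CC3)C2)cc1` has not yet been measured. It differs from compound 2 in one place: diethylamino in place of cyclobutyl on a sulfonyl sulfur with diethylamino in place of cyclobutyl on a sulfonyl sulfur. Among the measured compounds shown here, no measured pair shows this change alone, so its size can only be judged indirectly. Compound 3 carries the same diethylsulfamoyl group on a different remainder and stands at 400 nM on this evidence, which points to a small expected move toward a higher number in this assay rather than a gain. The expected step is a 1.9-fold higher number from compound 2 to compound 4 (0.27 log units; within the scatter) overall. For compound 4 the estimated value is 130 nM with an expected range of 40 nM to 420 nM once it is tested.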

Compound 4, half-maximal inhibitory concentration: 50 nM
Compound 4: the middle estimate sits 2.6-fold (0.41 log units) above what was measured; low and high end bracket the measured number.
By their numbers in this assay, from the lowest: compounds 4 and 2 (each within the scatter of the next); then compound 3; then compound 1.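

In this assay, among the compounds shown here, this is the first pair that shows the change alone: diethylamino in place of cyclobutyl on a sulfonyl sulfur gives a 1.4-fold lower number from compound 2 to compound 4 (0.15 log units; within the scatter). On this remainder, the four-membered carbon ring and the open diethylamino group therefore cannot be told apart in this assay, which compound 1 and compound 3 could not show, as each differs from compound 2 in more than one place. Nothing measured here bears on why the two groups read alike. For the compounds shown here, whether the same holds on a different remainder stays open, as this single pair is the only direct comparison. Also open, on these data alone, is how a methyl group, a morpholine or a phenyl ring on that sulfonyl sulfur would read in this assay.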